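Compound 3: 4-ethylphenyl in place of 2-fluorophenyl

This account rests on a few compounds, and the source may have more. Where it says the series, first, only, none or still open, it means among the compounds named here.

Measured so far:
Compound 1 `COc1cccc(NC(=O)CSc2nc(Nc3ccccc3)c3ccccc3n2)c1`: 10000 nM
Compound 2 `C=CC(=O)Nc1cccc(NC(=O)CSc2nc(Nc3ccccc3F)c3ccccc3n2)c1`: 26100 nM

In a functional assay on MGC-803 cells (Homo sapiens) for inhibition, read by MTT assay, with a stated time of 72 h (on this read-out higher numbers stand for weaker inhibition and lower numbers for stronger inhibition), compound 1 gives 10000 nM. In this assay compound 2 gives 26100 nM, the higher of the two numbers, and its gap to compound 1 lies beyond the scatter. Among the compounds with values here, the two compounds differ in more than one place, so no single step connects them, and their values are taken only as they stand.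

Compound 3 `C=CC(=O)Nc1cccc(NC(=O)CSc2nc(Nc3ccc(CC)cc3)c3ccccc3n2)c1` has not been measured. It keeps the whole of compound 2 apart from one change: 4-ethylphenyl in place of 2-fluorophenyl on a nitrogen on an aromatic ring. Within the data shown here, no measured pair shows this change on its own, so nothing here tells how large its effect is. The step from compound 2 to compound 3 is expected to be small, a 1.7-fold lower number from compound 2 to compound 3 (0.24 log units; within the scatter), and may well fall within the scatter. Compound 3 is therefore estimated at 15000 nM, with a range from 5000 nM to 45000 nM.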

Compound 3, half-maximal inhibitory concentration: 8010 nM
For compound 3 the middle estimate is 1.9-fold (0.27 log units) above the measured one; the range from low to high includes it.
By their numbers in this assay, from the lowest: compounds 3 and 1 (each within the scatter of the next); then compound 2.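

In this assay the group on a nitrogen on an aromatic ring proves not to be indifferent: 4-ethylphenyl in place of 2-fluorophenyl gives a 3.3-fold lower number from compound 2 to compound 3 (0.51 log units; beyond the scatter) and so shows a modest effect at this place. Within the data shown here, this is the first step that changes one place alone, with the rest of compound 2 kept, so the shift can be assigned to this exchange of groups. Nothing available explains the shift.

The exchange removes fluorine and brings in ethyl in a single step, and the compounds shown do not separate these two parts. As far as these compounds go, it also remains open how this place would respond to a longer chain than ethyl, or to an amine or a carboxylic acid on the phenyl ring.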